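From a Branched Amine to a Ring Amine

A few compounds are considered here, and "the series" means these few. Any claim that something is new, unique, unknown or untested is made for them only; others in the source may bear on it.

Within the data shown here, compound 1 `CC(C)(C)Nc1nc(N)c(C(=O)N=C(N)N)nc1Cl` is the only compound here with a number: in an assay for inhibition of acid-sensing ion channel 3 (Homo sapiens), read by patch clamp, tested at 20 uM (on this read-out higher numbers stand for more inhibition at the one concentration tested (going by the name of the read-out) and lower numbers for less inhibition), compound 1 gives 48%. A second compound, compound 2 `NC(N)=NC(=O)c1nc(Cl)c(NCC2CCc3ccccc3C2)nc1N`, was run in this assay but compound 2 gives only "not determined" (no result reported), so no result was reported for it. Compound 3 `NC(N)=NC(=O)c1nc(Cl)c(N2CCCC2)nc1N` has not been measured yet. It differs from compound 1 in one place: pyrrolidin-1-yl in place of (tert-butyl)amino on an aromatic carbon. Among the measured compounds shown here, no measured pair shows how such a change plays out, so there is no measured step to lean on. The step of a number 6 percentage points lower from compound 1 to compound 3 (within the scatter) is expected to be a small decrease, close to the usual scatter. Compound 3 is therefore estimated at 42%, within 15% to 70%.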

Compound 3, a percentage reported as inhibition, at one concentration (the size of the read-out at that concentration, not a potency): 84%
Compound 3: middle estimate off by 42 percentage points, on the low side; measured number outside the range, above it.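

Swapping (tert-butyl)amino for pyrrolidin-1-yl gives a number 36 percentage points higher from compound 1 to compound 3 (beyond the scatter) in this assay, so this position responds strongly to the group it carries. Both groups have 5 heavy atoms (4 carbon, 1 nitrogen), so a large step arises with no change in those counts: the atoms now form a five-membered non-aromatic ring, and the hydrogen-bond donor is gone. No measurement at hand explains the step. As far as these compounds go, whether the ring or the missing donor matters more stays open. A dimethylamino group, which has no such donor and no ring, or a larger piperidin-1-yl ring could help separate these features.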